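A few compounds are considered here, and "the series" means these few. Any claim that something is new, unique, unknown or untested is made for them only; others in the source may bear on it.

Measured in a functional assay on A549 cells (Homo sapiens) for inhibition, read by MTT assay, with a stated time of 72 h; on this read-out higher numbers stand for weaker inhibition and lower numbers for stronger inhibition:
- compound 1 `O=C(CCC(=O)OCCCCCCSc1ccc([N+](=O)[O-])c2nonc12)Nc1ccc(Br)cc1`: 3340 nM
- compound 2 `O=C(CCC(=O)OCCCCCCSc1ccc([N+](=O)[O-])c2nonc12)Nc1ccc(C(F)(F)F)cc1`: 4020 nM
- compound 3 `O=C(CCC(=O)OCCCCCCSc1ccc([N+](=O)[O-])c2nonc12)Nc1ccc(F)c(Cl)c1`: 3210 nM

Compound 3 stands within the scatter of both compound 1 and compound 2. Compound 4 `CN(C)CCNC(=O)CCC(=O)OCCCCCCSc1ccc([N+](=O)[O-])c2nonc12`, not yet measured, differs from compound 3 by 2-(dimethylamino)ethyl in place of 3-chloro-4-fluorophenyl on an amide-type nitrogen. The three measured steps that bear on this are a 1.2-fold higher number from compound 1 to compound 2 (0.08 log units; within the scatter), a 1.0-fold lower number from compound 1 to compound 3 (0.02 log units; within the scatter) and a 1.3-fold lower number from compound 2 to compound 3 (0.10 log units; within the scatter). All lie within the scatter, but each keeps an aromatic ring on the amide-type nitrogen, so none tests the loss of that ring. In this assay, no shift beyond the scatter is therefore expected, though with limited confidence. The estimated change is a 1.4-fold higher number from compound 3 to compound 4 (0.15 log units; within the scatter). For compound 4 the estimated value is 4500 nM, with an expected range of 1500 nM to 13000 nM.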

Compound 4, half-maximal inhibitory concentration: 5550 nM
For compound 4 the middle estimate is 1.2-fold (0.09 log units) below the measured one, and the stated range covers the measured number.
By their numbers in this assay, from the lowest: compounds 3, 1, 2 and 4 (each within the scatter of the next).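

In this assay, putting the ringless 2-(dimethylamino)ethyl on the amide-type nitrogen in place of an aromatic ring gives a 1.7-fold higher number from compound 3 to compound 4 (0.24 log units; within the scatter) and a 1.4-fold higher number from compound 2 to compound 4 (0.14 log units; within the scatter) and a 1.7-fold higher number from compound 1 to compound 4 (0.22 log units; within the scatter) and all three steps lie within the scatter. The earlier compounds shown here carried only substituted phenyl groups at this position, whereas compound 4 shows that losing the ring altogether brings no shift beyond the scatter in this assay. Nothing measured here explains this result. Still open, from the compounds shown here alone, is whether a carboxylic acid in place of the dimethylamino group, or a longer chain carrying that same amine, would also stay within the scatter.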